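Swapping a methyl for a hydroxy on a fused-ring core

The compounds below may be only part of what the source reports. "The series", "measured", "known", "first", "only" and "open" are said of these compounds alone.

Compound 1 `CNc1nc(N)c2nc(O)n(Cc3ccccc3)c2n1` and compound 2 `Cc1nc(N)c2nc(O)n(Cc3ccccc3)c2n1` share one core and differ in a single group. In a functional assay (spleen, spleen) for activation, with Mus musculus as the target (on this read-out lower numbers stand for an effect already at smaller amounts and higher numbers for an effect only at larger amounts of compound), compound 1 gives 1 uM, and compound 2 gives 1 uM. The step of no change at the digits printed from compound 1 to compound 2 (within the scatter) shows that exchanging methylamino for methyl at this position of the core left the read-out unchanged. For the measured compounds named here, compound 2 therefore stands level with compound 1 on the numbers so far.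

Compound 3 `Nc1nc(O)nc2c1nc(O)n2Cc1ccccc1` is the next case. Its difference from compound 2 is hydroxy in place of methyl on an aromatic carbon. Going by the values given here, the only step that bears on this position is the one from compound 1 to compound 2, which was within the scatter, so a change of group at this place has so far not moved the read-out. On that basis compound 3 is expected to show a step of no change at the digits printed from compound 2 to compound 3 (within the scatter) in this assay, that is, no shift beyond the scatter. The estimate for compound 3 is 1 uM, within a range from 0.3 uM to 3 uM.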

Compound 3, minimum effective concentration: 0.1 uM
Compound 3: middle estimate off by 10-fold (1.00 log units), on the high side; measured number below the stated range.
By their numbers in this assay, from the lowest: compound 3; then compounds 1 and 2 (each within the scatter of the next).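

In this assay, hydroxy in place of methyl on an aromatic carbon gives a 10-fold lower number from compound 2 to compound 3 (1.00 log units; beyond the scatter), and hydroxy in place of methylamino at the same place gives a 10-fold lower number from compound 1 to compound 3 (1.00 log units; beyond the scatter). This position therefore looked indifferent only while methyl and methylamino were being compared: it does respond to the group it carries, and among the three groups shown, hydroxy gives an effect at the smallest amount of compound. Nothing measured here explains why hydroxy stands apart from the other two groups.

From the compounds shown here alone, whether this lower number belongs to hydroxy alone remains open, and a methoxy group, a plain amine or a chlorine atom on this carbon would help to settle that. Going by these compounds, the three compounds also share every other part, so how far the step depends on the rest of the molecule is unknown.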